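A Cyano Group in Place of a Larger One

The source may hold more compounds than are shown below. What is called first, only, known or untested is meant among the compounds shown, and "the series" means these compounds.

Three compounds share one core and differ only at the edges. Compound 1, `Cc1c(C=O)cc(-c2ccc(S(C)(=O)=O)cc2)n1-c1cccc(F)c1`, is tested in a functional assay on the whole organism (strain Swiss albino) for inhibition, with Mus musculus as the target, in the writhing test, with a stated time of 30 min, at a dose of 20 mg/kg by the oral route (a higher number here means a stronger effect of the compound at the dose given, a lower number a weaker effect), where compound 1 gives 44%. Compound 2, `Cc1c(/C=N\O)cc(-c2ccc(S(C)(=O)=O)cc2)n1-c1cccc(F)c1`, gives 42% in this assay, and compound 3, `Cc1c(/C=N\O)cc(-c2ccc(S(C)(=O)=O)cc2)n1-c1ccccc1`, gives 53%. Among these three numbers compound 2 stands lowest; its nearest neighbour is compound 1, separated by a number 2 percentage points lower from compound 1 to compound 2 (within the scatter), while the larger gap is a number 11 percentage points higher from compound 2 to compound 3 (beyond the scatter).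

Compound 4, `Cc1c(C#N)cc(-c2ccc(S(C)(=O)=O)cc2)n1-c1cccc(F)c1`, has not yet been measured. It differs from compound 2 in one place: a group of 2 heavy atoms (1 carbon, 1 nitrogen; no ring) in place of a group of 3 heavy atoms (1 carbon, 1 nitrogen, 1 oxygen; no ring), on an aromatic carbon. Both the leaving and the entering group sit on an aromatic carbon of the five-membered aromatic ring with one nitrogen, next to the ring atom that bears a methyl group.

Going by the values given here, only one measured step touches this position, the one from compound 1 to compound 2, and it changed the group there without moving this assay beyond the scatter. The step from compound 2 to compound 3 alters a different part of the molecule and does not speak to this change. Because a number 2 percentage points lower from compound 1 to compound 2 (within the scatter) lay within the scatter, a step of similar size is expected for compound 4: a number 2 percentage points higher from compound 2 to compound 4 (within the scatter). Compound 4 is therefore estimated at 44%, with a likely range from 30% to 58%.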

Compound 4, a percentage reported as inhibition, in the whole organism at one dose (the size of the read-out at that dose, not a potency): 33%
Estimate against measurement, compound 4: 11 percentage points above; low and high end bracket the measured number.
By their numbers in this assay, from the lowest: compounds 4, 2, 1 and 3 (each within the scatter of the next, the first and the last beyond it).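

In this assay, going by these compounds alone, the aromatic carbon next to the ring atom that bears a methyl group now shows a change that passes the scatter, since cyano in place of formyl gives a number 11 percentage points lower from compound 1 to compound 4 (beyond the scatter) and the one earlier step at this position did not pass it. The same cyano group set against the group of compound 2 gives a number 9 percentage points lower from compound 2 to compound 4 (within the scatter) and so stays inside the scatter, which means the position is not shown to be sensitive to every change and the effect seen here is modest, readable only against formyl. No measurement offered here accounts for the drop seen with the cyano group, so the result stands as an observation without an explanation.

The compounds shown leave open what a carboxylic acid, an aminomethyl group or a longer chain at this position would do to the read-out. As far as these compounds go, they also pair the cyano group only with the 3-fluorophenyl group, so it stays open whether hydrogen in place of fluoro, which elsewhere gave a number 11 percentage points higher from compound 2 to compound 3 (beyond the scatter), would bring a similar step in a cyano compound.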